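Toward Compound 3: A Methoxy for a Trifluoromethyl

This account rests on a few compounds, and the source may have more. Where it says the series, first, only, none or still open, it means among the compounds named here.

Compound 1, `COc1ccc(-n2nc(-c3ccc(C(F)(F)F)cc3O)nc2-c2ccccc2O)cc1`: 98.9%
Compound 2, `Oc1cc(C(F)(F)F)ccc1-c1nc(-c2ccccc2O)n(-c2cccc(C(F)(F)F)c2)n1`: 99.9%

In a functional assay on PC-12 cells (Rattus norvegicus) for cytotoxicity, read by MTT assay, with stated times of 2 h and 24 h, tested at 10 uM (on this read-out lower numbers stand for a weaker effect and higher numbers for a stronger effect at the one concentration tested), compound 2 gives 99.9%, while compound 1 gives 98.9%; both sit near the top of the scale, and a number 1 percentage points higher from compound 1 to compound 2 (within the scatter). Compound 3, `COc1cccc(-n2nc(-c3ccc(C(F)(F)F)cc3O)nc2-c2ccccc2O)c1`, differs from compound 2 in one place: methoxy in place of trifluoromethyl on an aromatic carbon. Going by the values given here, the only measured step, from compound 1 to compound 2, also swapped groups on that same ring and moved the read-out by nothing beyond the scatter. Compound 3 is therefore expected to stay high in this assay, at 96% with a range of 82% to 100%, a change of a number 3.9 percentage points lower from compound 2 to compound 3 (within the scatter) from compound 2 that is estimated to lie within the scatter.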

Compound 3, a percentage reported as activity, at one concentration (the size of the read-out at that concentration, not a potency): 106%
For compound 3 the middle estimate is 10 percentage points below the measured one; measured number outside the range, above it.
By their numbers in this assay, from the lowest: compounds 1, 2 and 3 (each within the scatter of the next).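

With methoxy in place of trifluoromethyl on an aromatic carbon, the read-out in this assay stays within the scatter (a number 6.1 percentage points higher from compound 2 to compound 3 (within the scatter)), so this position tolerates a swap of the group itself. Moving the methoxy, as 3-methoxyphenyl in place of 4-methoxyphenyl on an aromatic nitrogen, also stays within the scatter (a number 7.1 percentage points higher from compound 1 to compound 3 (within the scatter)). No measurement at hand explains either result. The compounds shown leave open whether an amine or a carboxylic acid on this ring would lower the read-out. Because all three compounds sit near the top of the scale, they also leave open how far this position can influence it.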